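From cyclopentylmethyl to phenyl on the carbonyl carbon

The compounds below may be only part of what the source reports. "The series", "measured", "known", "first", "only" and "open" are said of these compounds alone.

Of the compounds shown here, three built on one shared core have been measured in an assay on LtK cells with ATP-sensitive inward rectifier potassium channel 11 (Homo sapiens) as the target; on this read-out lower numbers stand for an effect already at smaller amounts and higher numbers for an effect only at larger amounts of compound. Compound 1 `CCC(CC)C(=O)Nc1c(C(O)(C(F)(F)F)C(F)(F)F)ccc2ccccc12` gives 4340 nM. Compound 2 `CCCC(C)C(=O)Nc1c(C(O)(C(F)(F)F)C(F)(F)F)ccc2ccccc12` reaches only the limit of > 10000 nM (the limit of > 10000 nM in this assay, at which 1 of the 3 values shown sits). Compound 3 `O=C(CC1CCCC1)Nc1c(C(O)(C(F)(F)F)C(F)(F)F)ccc2ccccc12` gives 81 nM, the lowest number among the values shown; its nearest neighbour is compound 1, and the step of a 54-fold lower number from compound 1 to compound 3 (1.73 log units; beyond the scatter) is large, while an at least 120-fold lower number from compound 2 to compound 3 (2.09 log units; beyond the scatter) is larger still. Among the two open chains, an at least 2.3-fold higher number from compound 1 to compound 2 (0.36 log units; beyond the scatter) is at least modest. Taken together, the branched groups pentan-3-yl and 1-methylbutyl on the carbonyl carbon go with high numbers, whereas cyclopentylmethyl goes with a low one.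

Compound 4 `O=C(Nc1c(C(O)(C(F)(F)F)C(F)(F)F)ccc2ccccc12)c1ccccc1` differs from compound 3 by phenyl in place of cyclopentylmethyl on a carbonyl carbon. Going by the values given here, no measured step exchanges one ring for another, so this change is not covered directly. What the measured steps do show is that the group on the carbonyl carbon can move the number a great deal, so a sizeable shift would not surprise. The author expects the number to rise from compound 3 to compound 4, a 6.2-fold higher number from compound 3 to compound 4 (0.79 log units; beyond the scatter). Compound 4 is therefore estimated at 500 nM, with a range from 100 nM to 4000 nM.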

Compound 4, half-maximal effective concentration: 44 nM
Compound 4: the middle estimate sits 11-fold (1.06 log units) above what was measured, outside the stated range (below it).
By their numbers in this assay, from the lowest: compounds 4 and 3 (each within the scatter of the next); then compound 1. At a limit, above all of these: compound 2.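

In this assay, the exchange of cyclopentylmethyl for phenyl on the carbonyl carbon stays within the scatter, a 1.8-fold lower number from compound 3 to compound 4 (0.27 log units; within the scatter), so among these compounds a low number at this position is not tied to the five-membered non-aromatic ring: a six-membered aromatic ring of carbon only, with the same count of heavy atoms, goes with it as well. Phenyl also stands far from the open chain pentan-3-yl, a 99-fold lower number from compound 1 to compound 4 (1.99 log units; beyond the scatter), which means that among these four compounds the two ring-bearing groups now go with low numbers and the two open branched chains with high numbers, and no compound goes against this. The step of an at least 220-fold lower number from compound 2 to compound 4 (2.35 log units; beyond the scatter) rests on a limit, not on a number: the limit of > 10000 nM in this assay, at which 1 of the 4 values shown sits.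

The compounds shown leave open whether cyclopentyl placed directly on the carbonyl carbon, or benzyl, would go with equally low numbers, which would separate the type of ring from the carbon that links it. They also leave open how a pyridyl ring, or a phenyl ring carrying a chlorine or a methoxy group, would read in this assay.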